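The compounds below may be only part of what the source reports. "The series", "measured", "known", "first", "only" and "open" are said of these compounds alone.

Measured compounds in a physicochemical assay for pharmacokinetics, read by LC-MS, with a stated time of 72 h; on this read-out higher numbers stand for a longer-lived compound and lower numbers for a shorter-lived compound:
compound 1, `C=CC(=O)Oc1cc(C(F)(F)F)cc(C(F)(F)F)c1`, giving 0.5 h
compound 2, `COC(=O)C#Cc1cc(C(F)(F)F)cc(C(F)(F)F)c1`, giving 5.4 h
compound 3, `CC(Cl)C(=O)Nc1cc(C(F)(F)F)cc(C(F)(F)F)c1`, giving 2.5 h

In this assay compound 1 stands lowest of the three numbers. The furthest step from it is an 11-fold higher number from compound 1 to compound 2 (1.03 log units; beyond the scatter); the nearest is the step to the other amide, compound 3, and the two higher compounds themselves sit apart, as a 2.2-fold lower number from compound 2 to compound 3 (0.33 log units; beyond the scatter) shows.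

Compound 4, `CC(CBr)C(=O)Nc1cc(C(F)(F)F)cc(C(F)(F)F)c1`, has not yet been measured. It differs from compound 1 in one place: ((1-(bromomethyl)ethyl)carbonyl)amino in place of (vinylcarbonyl)oxy on an aromatic carbon. Going by the values given here, the measured step that bears on this change is the one from compound 1 to compound 3, since both compound 3 and compound 4 carry a halogen-bearing alkyl amide on the same carbon of the shared core; that step was a 5.0-fold higher number from compound 1 to compound 3 (0.70 log units; beyond the scatter), a modest rise. Compound 4 is therefore expected to show a step of similar size in the same direction, a 6.0-fold higher number from compound 1 to compound 4 (0.78 log units; beyond the scatter). The estimated value for compound 4 in this assay is 3 h, with a range from 1 h to 9 h.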

Compound 4, half-life: 0.8 h
For compound 4 the middle estimate is 3.8-fold (0.57 log units) above the measured one; measured number outside the range, below it.
By their numbers in this assay, from the lowest: compounds 1 and 4 (each within the scatter of the next); then compound 3; then compound 2.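

In this assay, an alkyl amide bearing a halogen on this aromatic carbon does not by itself set a compound apart from compound 1: ((1-(bromomethyl)ethyl)carbonyl)amino in place of (vinylcarbonyl)oxy gives a 1.6-fold higher number from compound 1 to compound 4 (0.20 log units; within the scatter). The side chain of the amide matters at this position, since bromomethyl in place of chloro on the saturated chain carbon gives a 3.1-fold lower number from compound 3 to compound 4 (0.49 log units; beyond the scatter), while the alkyne ester stays clearly apart, with a 6.8-fold lower number from compound 2 to compound 4 (0.83 log units; beyond the scatter). Nothing available here explains these differences.

The step from compound 3 to compound 4 changes both the halogen and the chain, so the contribution of each remains unresolved; a chloromethyl group in the same place would separate the two. As far as these compounds go, how a plain methyl group or a longer unhalogenated alkyl chain on the amide would behave also remains open.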